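A few compounds are considered here, and "the series" means these few. Any claim that something is new, unique, unknown or untested is made for them only; others in the source may bear on it.

Measured so far:
compound 1, `COC(=O)C1=C(C)NC(=O)NC1c1ccoc1`: 2%
compound 2, `CCCOC(=O)C1=C(C)NC(=S)NC1c1ccco1`: 1%
compound 3, `COC(=O)C1=C(C)NC(=S)NC1c1ccoc1`: 3%

These three compounds were tested in an assay on membranes from HeLa cells for displacement of a labelled ligand from adenosine receptor A3 (Homo sapiens), read by scintillation counting, with a stated time of 180 min, tested at 1 uM; on this read-out lower numbers stand for less inhibition and higher numbers for more inhibition at the one concentration tested (going by the name of the read-out). In this assay compound 1 gives 2%, compound 2 gives 1% and compound 3 gives 3%. The number for compound 3 is the highest of the three, but its nearest neighbour, compound 1, and its furthest, compound 2, both lie within the usual scatter of it, so the three numbers cannot be told apart and no order can be read from them. Compound 2 differs from compound 3 in more than one place, so its value says nothing on its own about any single change.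

The next compound, compound 4, has the structure `CCCOC(=O)C1=C(C)NC(=S)NC1c1ccoc1`. It differs from compound 3 in one place: ethyl in place of hydrogen on a saturated chain carbon bound to an oxygen next to a carbonyl group.

Among the measured compounds shown here, no measured pair in this set shows this change on its own. Since every number seen so far is small and all lie within the scatter of one another, the step from compound 3 to compound 4 is expected to be no change at the digits printed from compound 3 to compound 4 (within the scatter), a change that stays inside the scatter rather than a real rise or fall. Compound 4 is therefore estimated to give 3% in this assay. For compound 4 the expected range runs from 0% to 12%.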

Compound 4, a percentage reported as inhibition, at one concentration (the size of the read-out at that concentration, not a potency): 3%
The estimate for compound 4 equals the measured number at the digits printed, within the range that was stated.
By their numbers in this assay, from the lowest: compounds 2, 1, 3 and 4 (each within the scatter of the next).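

In this assay the ester position now has its first reading of a single change: going from methoxycarbonyl to propoxycarbonyl, with ethyl in place of hydrogen on a saturated chain carbon bound to an oxygen next to a carbonyl group, gives no change at the digits printed from compound 3 to compound 4 (within the scatter), so this added ethyl does not move the number beyond the scatter. Among the compounds shown here, the new compound also gives a first reading at a second place, where furan-3-yl in place of furan-2-yl on a saturated ring carbon gives a number 2 percentage points higher from compound 2 to compound 4 (within the scatter), and this swap likewise stays inside the scatter. Nothing available bears on why these numbers stay so small.

Still open, from the compounds shown here alone, is whether a longer chain such as octyl, a benzyl group or a chain ending in an amine or a carboxylic acid in place of the propyl would give a number clear of the scatter. With every reading taken at one concentration and all of them small, the compounds shown also leave open whether either of these two changes would matter in a compound with a clearly higher number.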